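Extending the ring-nitrogen alkyl chain of compound 1

The compounds below may be only part of what the source reports. "The series", "measured", "known", "first", "only" and "open" are said of these compounds alone.

Measured compounds:
compound 1, `Cc1nn(C)c2c(O)nc(Cc3ccccc3)nc12`, 1310 nM
compound 2, `Cn1c(=O)c2nc(-c3ccc(Cl)cc3)[nH]c2n(C)c1=O`, 0.8 nM
compound 3, `Cn1c(=O)c2nc(-c3cccc(N)c3)[nH]c2n(C)c1=O`, 10 nM

In an assay on membranes from brain for binding affinity to adenosine receptor A1 (Rattus norvegicus), read by radioligand binding (on this read-out lower numbers stand for stronger inhibition and higher numbers for weaker inhibition), compound 1 gives the highest of the three numbers. Its nearest neighbour on this read-out is compound 3, whose value lies far lower, well beyond the scatter, and compound 2 lies further still, also beyond the scatter. Among the measured compounds shown here, compounds 2 and 3 share a core different from that of compound 1, so the two sets of values show only that compound 1 is the weakest binder of the three.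

Compound 4, `CCn1nc(C)c2nc(Cc3ccccc3)nc(O)c21`, keeps the core, the benzyl group and the hydroxyl of compound 1 and differs from it in one place: methyl in place of hydrogen on a saturated chain carbon bound to an aromatic nitrogen. Cut one bond further out, the change reads as methyl to ethyl on the ring nitrogen.

For the measured compounds named here, no measured pair in this set mirrors that change, so its size in this assay is unknown. A single added carbon on a chain attached to the ring nitrogen is expected to move the value little, most likely not beyond the scatter in either direction. Compound 4 is therefore estimated at 1000 nM, within 350 nM to 3500 nM, which corresponds to an expected step of a 1.3-fold lower number from compound 1 to compound 4 (0.12 log units; within the scatter).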

Compound 4, half-maximal inhibitory concentration: 820 nM
The estimate for compound 4 lay 1.2-fold (0.09 log units) above the measured number; the measured number falls inside the stated range.
By their numbers in this assay, from the lowest: compound 2; then compound 3; then compounds 4 and 1 (each within the scatter of the next).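

Going from methyl to ethyl on the ring nitrogen gives, in this assay, a 1.6-fold lower number from compound 1 to compound 4 (0.20 log units; within the scatter), so at this place, on a saturated chain carbon bound to an aromatic nitrogen, the added methyl leaves a difference that cannot be told from the scatter. Among the compounds shown here, the earlier compounds could not show this: compounds 2 and 3 carry a different core, and this pair is the first in the set to differ in one place only. The data offer no measurement that bears on why the ring nitrogen tolerates the ethyl group as they stand.

On these data alone, whether the position would accept more than one added carbon stays open: a longer chain such as propyl or butyl, a branched isopropyl group, or a chain ending in an amine or a carboxylic acid could each give a value that stays close to those of compound 1 and compound 4 or one that departs from them. Compounds 2 and 3 differ from compound 4 in more than one place, so what separates their far lower numbers from this pair also remains unresolved.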